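A few compounds are considered here, and "the series" means these few. Any claim that something is new, unique, unknown or untested is made for them only; others in the source may bear on it.

Measured so far:
Compound 1 `C#CCOC(=O)/C(C)=C/CC/C(C)=C/CC/C(C)=C/CC[C@@H]1[C@@]2(C)CCC(=O)C(C)(C)[C@H]2CC[C@@]1(C)O`: 45100 nM
Compound 2 `C/C(=C\CC/C(C)=C/CC[C@@H]1[C@@]2(C)CCC(=O)C(C)(C)[C@H]2CC[C@@]1(C)O)CC/C=C(\C)C(=O)OCc1cn(-c2ccc(Br)cc2)nn1`: > 150000 nM

In a functional assay on A549 cells (Homo sapiens) for antiproliferative activity, read by MTT assay, with a stated time of 48 h (a lower number here means a stronger inhibitor, a higher number a weaker inhibitor), compound 2 stands at > 150000 nM, which is a limit and not a number. Compound 3 `C/C(=C\CC/C(C)=C/CC[C@@H]1[C@@]2(C)CCC(=O)C(C)(C)[C@H]2CC[C@@]1(C)O)CC/C=C(\C)C(=O)OCc1cn(-c2cccc(Cl)c2)nn1` differs from it in one group: 3-chlorophenyl in place of 4-bromophenyl on an aromatic nitrogen. Among the measured compounds shown here, the only measured step, an at least 3.3-fold higher number from compound 1 to compound 2 (0.52 log units; beyond the scatter), lies beyond the scatter, but it replaced ethynyl with the whole 1-(4-bromophenyl)-1H-1,2,3-triazol-4-yl group and ends at a limit, so it gives no direction for this smaller swap. The expected change in this assay is therefore an at least 1.1-fold lower number from compound 2 to compound 3 (0.06 log units; that floor lies within the scatter), with no shift beyond the scatter. The estimate for compound 3 is 130000 nM, with an expected range of 60000 nM to 250000 nM.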

Compound 3, half-maximal inhibitory concentration: 147000 nM
Beside the measured number, compound 3's estimate is 1.1-fold (0.05 log units) below it, within the range that was stated.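

With 1-(3-chlorophenyl)-1H-1,2,3-triazol-4-yl in place of ethynyl, the loss against compound 1 now has a measured size in this assay: a 3.3-fold higher number from compound 1 to compound 3 (0.51 log units; beyond the scatter). Replacing 4-bromophenyl with 3-chlorophenyl on the aromatic nitrogen gives an at least 1.0-fold lower number from compound 2 to compound 3 (0.00 log units; that floor lies within the scatter), so this swap shows no readable gain. Compound 2 has only a limit, so this step has a floor and no true size: the limit of > 150000 nM in this assay, at which 1 of the 3 values shown sits.

The halogen and its ring place changed together, so neither can be judged alone. Going by these compounds, whether a 4-aminophenyl group on this aromatic nitrogen would bring the number closer to that of compound 1 remains open.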